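Swapping Chloro for Methoxy on the Pendant Aryl Ring

A few compounds are considered here, and "the series" means these few. Any claim that something is new, unique, unknown or untested is made for them only; others in the source may bear on it.

Compound 1 `COc1cc(/C=C/C(=O)c2cccc(-n3cc(-c4ccc(Cl)cc4)[nH]c3=O)c2)cc(OC)c1OC` is assessed in a functional assay on TK-10 cells (Homo sapiens) for inhibition (a lower number here means a stronger inhibitor of growth, a higher number a weaker inhibitor of growth), where compound 1 gives 6460 nM. Two companions share its core. Compound 3 `O=C(/C=C/c1cccc(O)c1)c1cccc(-n2cc(-c3ccc(Cl)cc3)[nH]c2=O)c1` carries the same 4-chlorophenyl group but a hydroxyphenyl in place of the trimethoxyphenyl, and in this assay compound 3 gives 2830 nM. Compound 2 `O=C(/C=C/c1cccc(O)c1)c1cccc(-n2cc(-c3ccccc3)[nH]c2=O)c1` has an unsubstituted phenyl, and for compound 2 the result in this assay is "not determined" (no result reported). Among the two numbers, compound 1 stands highest, with compound 3 the nearer of the pair at a gap that lies beyond the usual scatter.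

Compound 4 `COc1ccc(-c2cn(-c3cccc(C(=O)/C=C/c4cc(OC)c(OC)c(OC)c4)c3)c(=O)[nH]2)cc1` follows from compound 1 by a single change, (methoxy in place of chloro on an aromatic carbon). For the measured compounds named here, no pair of measured compounds shows this change on its own, so its effect has to be estimated without a direct precedent. Given that the aryl groups on the remaining compounds differ elsewhere, the expectation for compound 4 is a step of modest size, most likely no larger than the scatter, with no firm direction. On that basis compound 4 is expected to give 6000 nM, within a range from 2500 nM to 15000 nM, which corresponds to an expected step of a 1.1-fold lower number from compound 1 to compound 4 (0.03 log units; within the scatter).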

Compound 4, concentration for 50% growth inhibition: 3040 nM
The estimate for compound 4 lay 2.0-fold (0.30 log units) above the measured number; measured number inside the range.
By their numbers in this assay, from the lowest: compounds 3 and 4 (each within the scatter of the next); then compound 1.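

For the compounds shown here, replacing chloro with methoxy on the aromatic carbon para to a large group gives a 2.1-fold lower number from compound 1 to compound 4 (0.33 log units; beyond the scatter) in this assay, the first reading in this set of a change at this position taken on its own. The step shows that the group at this position matters for growth inhibition: with the trimethoxyphenyl end and the shared core held fixed, the 4-methoxyphenyl compound 4 inhibits growth more strongly than the 4-chlorophenyl compound 1, although the size of the step is modest. This single pair shows that the change has an effect in this one setting, but nothing measured here explains the step.

As far as these compounds go, compound 2 has no number in this assay, so the unsubstituted phenyl offers no baseline against which to judge either chloro or methoxy, and it remains open whether the same change would give a similar step with the hydroxyphenyl group of compound 3. Also open, from the compounds shown here alone, is how a fluoro group, a dimethylamino group or a carboxylic acid at this position would compare with methoxy.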